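From 4-fluorophenoxy to (4-methoxyphenyl)sulfanyl on a shared core

The compounds below may be only part of what the source reports. "The series", "measured", "known", "first", "only" and "open" are said of these compounds alone.

Of the compounds shown here, three with the same core have been measured in a functional assay on PC-3 cells (Homo sapiens) for inhibition, read by sulforhodamine B assay, with a stated time of 48 h; on this read-out higher numbers stand for weaker inhibition of growth and lower numbers for stronger inhibition of growth. Compound 1 `Nc1cc(N)c2nc(-c3ccccc3)c(NCc3ccc(Cl)c(Cl)c3)nc2c1` gives 5130 nM in this assay. Compound 2 `Nc1cc(N)c2nc(-c3ccccc3)c(Sc3ccc(F)cc3)nc2c1` gives only a limit of the assay, < 100000 nM. Compound 3 `Nc1cc(N)c2nc(-c3ccccc3)c(Oc3ccc(F)cc3)nc2c1` gives 27500 nM, the highest of the two numbers shown; compound 1 sits at a lower number, beyond the usual scatter. Within the data shown here, the only step among measured compounds, a step that the limit leaves unreadable from compound 2 to compound 3, cannot be sized, since one of its two values is a limit (the limit of < 100000 nM in this assay, at which 1 of the 3 values shown sits).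

Compound 4 `COc1ccc(Sc2nc3cc(N)cc(N)c3nc2-c2ccccc2)cc1` is not yet measured. It differs from compound 3 in one place: (4-methoxyphenyl)sulfanyl in place of 4-fluorophenoxy on an aromatic carbon. The step from compound 2 to compound 3 bears on this change, as it also exchanges a sulfur-linked for an oxygen-linked aryl group, but its size is unreadable. Compound 4 is therefore expected to stay near compound 3, with a step of a 1.3-fold higher number from compound 3 to compound 4 (0.10 log units; within the scatter) that may lie within the scatter or lean weaker. The estimate for compound 4 is 35000 nM, with a range from 10000 nM to 100000 nM.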

Compound 4, concentration for total growth inhibition: 5130 nM
Estimate against measurement, compound 4: 6.8-fold (0.83 log units) above; the measured number lies below the stated range.
By their numbers in this assay, from the lowest: compounds 1 and 4 (each within the scatter of the next); then compound 3.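

In this assay, among these compounds, the exchange at this aromatic carbon, next to the ring nitrogen, gives a 5.4-fold lower number from compound 3 to compound 4 (0.73 log units; beyond the scatter) as the first readable step among the aryl-bearing compounds. An aryl group held through sulfur therefore gives stronger inhibition of growth here than the oxygen-linked group of compound 3, and compound 1 shares its printed number with compound 4 at 5130 nM despite carrying a different group at this position. The steps from compound 2 cannot be read, because each of them rests on a limit of the assay: the limit of < 100000 nM in this assay, at which 1 of the 4 values shown sits.

Going by these compounds, the step to compound 4 changes the linking atom and the substituent on the phenyl ring together, so how much each contributes remains open. Also open, on these data alone, is whether an amine or a carboxylic acid in place of the methoxy group would keep this level of inhibition.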